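The compounds below may be only part of what the source reports. "The series", "measured", "known", "first", "only" and "open" are said of these compounds alone.

Measured so far:
compound 1 `CC(/C=N/Nc1ccc([N+](=O)[O-])cc1)=N\NC(=O)c1ccc(N)cc1` — > 12000 nM
compound 2 `CC(/C=N/N(C)c1ccc([N+](=O)[O-])cc1)=N\NC(=O)c1ccccc1O` — 3120 nM

In a functional assay on cells (Splenocyte, Mus musculus, strain BALB/c) for inhibition, read by scintillation counting and thymidine incorporation, with a stated time of 72 h (a lower number here means a stronger inhibitor, a higher number a weaker inhibitor), compound 1 gives only a limit, > 12000 nM, not a number. Compound 2 holds the only number shown in this assay, 3120 nM. Compound 3 `CC(/C=N/N(C)c1ccc([N+](=O)[O-])cc1)=N\NC(=O)c1ccc(N)cc1` carries 4-aminophenyl in place of 2-hydroxyphenyl on a carbonyl carbon. Among the compounds with values here, no measured step covers this change; compound 1, which bears the same 4-aminophenyl, sits at the limit of > 12000 nM in this assay, at which 1 of the 2 values shown sits, so a loss of potency beyond the scatter is expected, the step from compound 2 to compound 3 being a 2.9-fold higher number from compound 2 to compound 3 (0.46 log units; beyond the scatter). Compound 3 is therefore expected at 9000 nM, between 3000 nM and 27000 nM.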

Compound 3, half-maximal inhibitory concentration: > 12000 nM
Compound 3: no number, only a limit (the forecaster's own chance of this, stated with the estimate: 40%); at least 1.3-fold (0.12 log units) between middle value and limit.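

In this assay, within the data shown here, 4-aminophenyl in place of 2-hydroxyphenyl on a carbonyl carbon gives an at least 3.8-fold higher number from compound 2 to compound 3 (0.58 log units; beyond the scatter) as the first readable step at this position. Compound 3 gives only a limit and not a number: the limit of > 12000 nM in this assay, at which 2 of the 3 values shown sit. The step from compound 1 to compound 3 cannot be read, so methyl in place of hydrogen on that nitrogen has no size.

On these data alone, what 4-hydroxyphenyl or 2-aminophenyl on that carbonyl carbon would give stays open. The compounds shown therefore do not separate the change of group from the change of its place on the ring.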